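Adding a methoxy group to compound 3

A few compounds are considered here, and "the series" means these few. Any claim that something is new, unique, unknown or untested is made for them only; others in the source may bear on it.

Compound 3 `CC(C)c1c(Cc2c(F)cccc2F)nc(SCC(=O)c2ccccc2)[nH]c1=O` gives > 60000 nM in an ADME assay on MT4 cells (Homo sapiens) for cytotoxicity, read by MTT assay (on this read-out higher numbers stand for lower toxicity in this test and lower numbers for higher toxicity in this test), as a limit, not a number. Compound 4 `COc1ccc(C(=O)CSc2nc(Cc3c(F)cccc3F)c(C(C)C)c(=O)[nH]2)cc1` differs from compound 3 by methoxy in place of hydrogen on an aromatic carbon as methoxy in place of hydrogen on an aromatic carbon, turning phenyl into 4-methoxyphenyl. Compound 1 `COc1ccc(C(=O)CSc2nc(Cc3cccc4ccccc34)c(C(C)C)c(=O)[nH]2)cc1` already carries 4-methoxyphenyl and gives 203000 nM as a true number. Compound 2 `COc1ccc(C(=O)CSc2nc(Cc3c(F)cccc3Cl)c(C(C)C)c(=O)[nH]2)cc1` carries it too and gives > 11000 nM as a limit. Among the measured compounds shown here, the only measured step that the limit leaves unreadable from compound 1 to compound 2 concerns another group and offers no size to carry over. So in this assay no step beyond the scatter is expected, and the estimated move a step that the limit leaves unreadable from compound 3 to compound 4 stays small. The estimate for compound 4 is 70000 nM with an expected range from 20000 nM at the low end to 220000 nM at the high end.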

Compound 4, half-maximal cytotoxic concentration: 33000 nM
Beside the measured number, compound 4's estimate is 2.1-fold (0.33 log units) above it, within the range that was stated.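

In this assay, among the compounds shown here, the methoxy change gives an at least 1.8-fold lower number from compound 3 to compound 4 (0.25 log units; that floor lies within the scatter) so para to the large group it shows no step that clearly clears the scatter. With 4-methoxyphenyl held constant, swapping naphthalen-1-yl for 2,6-difluorophenyl gives a 6.2-fold lower number from compound 1 to compound 4 (0.79 log units; beyond the scatter) so changing that group can move this number beyond the scatter, towards higher toxicity in this test. The step from compound 2 to compound 4 and the step from compound 1 to compound 2 cannot be read: the limit of > 11000 nM in this assay, at which 1 of the 4 values shown sits.

Still open, going by these compounds, is how an amine or a carboxylic acid in place of the methoxy would read here.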